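A few compounds are considered here, and "the series" means these few. Any claim that something is new, unique, unknown or untested is made for them only; others in the source may bear on it.

Of the compounds shown here, three built on a shared core have been tested in an ADME assay on microsomes from liver (Homo sapiens) for metabolic stability, with a stated time of 30 min; a higher number here means that more of the compound is left, a lower number that less of the compound is left. Compound 1 `CCCCc1nc(C(C)C)c(CC(=O)OC2CC2)c(=O)n1Cc1ccc(-c2ccccc2-c2noc(=O)[nH]2)cc1` gives 10.3%. Compound 2 `CCCCc1nc(C)c(CC(=O)OC)c(=O)n1Cc1ccc(-c2ccccc2-c2noc(=O)[nH]2)cc1` gives 69.6%. Compound 3 `CCCCOC(=O)Cc1c(C)nc(CCCC)n(Cc2ccc(-c3ccccc3-c3noc(=O)[nH]3)cc2)c1=O` gives 2.8%. Among these three numbers compound 3 gives the lowest, but its value and that of compound 1 lie within the usual scatter of each other, so no order between those two can be claimed; only compound 2 stands clearly higher, beyond the scatter.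

Among the measured compounds shown here, the single measured step that touches the ester is a number 66.8 percentage points lower from compound 2 to compound 3 (beyond the scatter), brought about by propyl in place of hydrogen on a saturated chain carbon bound to an oxygen next to a carbonyl group. Growing the ester in this way was thus tied to a large loss in this assay.

Compound 4 `CCCCc1nc(C)c(CC(=O)OC2CC2)c(=O)n1Cc1ccc(-c2ccccc2-c2noc(=O)[nH]2)cc1` has not yet been measured. It differs from compound 3 by cyclopropyl in place of butyl on an oxygen next to a carbonyl group. The change runs partly back toward the small ester of compound 2, which would suggest a rise. Against a large rise stands compound 1, which carries the same cyclopropyl ester on a core that differs elsewhere and gives only 10.3%. A modest rise is therefore expected, a number 12.2 percentage points higher from compound 3 to compound 4 (beyond the scatter), with compound 4 estimated at 15%, likely between 4% and 40%.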

Compound 4, percent of the compound remaining: 34.5%
Estimate against measurement, compound 4: 19.5 percentage points below; the range from low to high includes it.
By their numbers in this assay, from the lowest: compounds 3 and 1 (each within the scatter of the next); then compound 4; then compound 2.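

In this assay the group on the oxygen next to a carbonyl group now shows three clearly separated outcomes on the shared core: cyclopropyl in place of butyl gives a number 31.7 percentage points higher from compound 3 to compound 4 (beyond the scatter) while cyclopropyl in place of methyl gives a number 35.1 percentage points lower from compound 2 to compound 4 (beyond the scatter) and so the cyclopropyl ester sits at a middle level, with the methyl ester of compound 2 highest and the butyl ester of compound 3 lowest. The same cyclopropyl ester also responds to a change elsewhere on the core: methyl in place of isopropyl on an aromatic carbon gives a number 24.2 percentage points higher from compound 1 to compound 4 (beyond the scatter) and this shows that the ester is not the only place that counts in this assay. Nothing measured here explains why these groups differ.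

On these data alone, it remains open where an ethyl or a propyl chain on that oxygen would fall, and so whether the ring of cyclopropyl matters or only the chain it replaces. Also open, as far as these compounds go, is how an amide or a carboxylic acid in place of the ester would behave, and whether the order of the esters holds with isopropyl on the core.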